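Cyclohexyl for benzyl on an amine of the shared core

A few compounds are considered here, and "the series" means these few. Any claim that something is new, unique, unknown or untested is made for them only; others in the source may bear on it.

Measured compounds in a functional assay on ECa-109 cells for inhibition, with ECa-109 cell line (Homo sapiens) as the target, read by sulforhodamine B assay; on this read-out higher numbers stand for weaker inhibition and lower numbers for stronger inhibition:
Compound 1 `O=C1C(N2CCCCC2)=CC(=O)c2c1nc1n2[C@H]2OC[C@@H](O)[C@H]2OC1`: > 8000 nM
Compound 2 `O=C1C=C(NCc2ccccc2)C(=O)c2c1nc1n2[C@H]2OC[C@@H](O)[C@H]2OC1`: > 8000 nM
Compound 3 `COc1ccccc1NC1=CC(=O)c2c(nc3n2[C@H]2OC[C@@H](O)[C@H]2OC3)C1=O`: > 4000 nM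

Each of these values is a limit of the assay, not a number. In this assay compound 2 sits at the limit (the limit of > 8000 nM in this assay, at which 2 of the 3 values shown sit). Compound 3 sits at a different limit, (the limit of > 4000 nM in this assay, at which 1 of the 3 values shown sits). Going by the values given here, the one step between measured compounds, a step that the two limits leave unreadable from compound 1 to compound 3, cannot be read because both ends are limits. Compound 4 `O=C1C=C(NC2CCCCC2)C(=O)c2c1nc1n2[C@H]2OC[C@@H](O)[C@H]2OC1` differs from compound 2 by cyclohexyl in place of benzyl on an amine nitrogen. Among the compounds with values here, no measured step bears on this change, and no value shown gives a number from which a direction could be taken. Compound 4 is therefore expected near the limit of compound 2, with the step that the limit leaves unreadable from compound 2 to compound 4 estimated as no change beyond the scatter. The estimate for compound 4 is 9000 nM, in the range 3000 nM to 30000 nM.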

Compound 4, half-maximal inhibitory concentration: > 16000 nM
Compound 4 was reported as a limit (the forecaster's own chance of this, stated with the estimate: 70%); middle value at least 1.7-fold (0.24 log units) away from the limit.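

Compound 2 and compound 4 are both reported only as limits of the assay, and the step between them cannot be read. The compounds shown leave open whether cyclohexyl in place of benzyl changes inhibition at all.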